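This account rests on a few compounds, and the source may have more. Where it says the series, first, only, none or still open, it means among the compounds named here.

Working notes on the series, read in a toxicity assay on MT4 cells (Homo sapiens) for cytotoxicity, read by MTT assay; on this read-out higher numbers stand for lower toxicity in this test and lower numbers for higher toxicity in this test. Going by the values given here, compound 1 `Cc1cc(-c2ccc(C#N)c(C#N)c2)ccc1Oc1cc(N)nc(Nc2ccc(C#N)cc2)n1` gives 76700 nM, the highest number of the three measured so far. Compound 2 `Cc1cc(-c2ccc(Cl)cc2)cc(C)c1Oc1cc(N)nc(Nc2ccc(C#N)cc2)n1` gives 21500 nM, and compound 3 `Cc1cc(-c2ccc(C#N)c(C#N)c2)cc(C)c1Oc1cc(N)nc(Nc2ccc(C#N)cc2)n1` gives 17600 nM. Compound 4 `Cc1cc(-c2cccc(C#N)c2)ccc1Oc1cc(N)nc(Nc2ccc(C#N)cc2)n1` has not yet been measured in this assay.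

Compound 4 departs from compound 1 by a single change, hydrogen in place of cyano on an aromatic carbon, turning 3,4-dicyanophenyl into 3-cyanophenyl. Among the compounds with values here, no measured step makes this exact change, so two steps bear on it only indirectly. Within the data shown here, exchanging 4-chlorophenyl for 3,4-dicyanophenyl gives a 1.2-fold lower number from compound 2 to compound 3 (0.09 log units; within the scatter), within the scatter, and this is the one comparison at the group that changes here. Methyl in place of hydrogen on an aromatic carbon gives a 4.4-fold lower number from compound 1 to compound 3 (0.64 log units; beyond the scatter), beyond the scatter, but that change lies elsewhere and compound 4 keeps the hydrogen of compound 1 there.

Among the measured compounds shown here, no step clearly beyond the scatter is therefore expected, with a slight lean to a lower number, as compound 1 at 76700 nM tops the three. The expected step is a 1.4-fold lower number from compound 1 to compound 4 (0.14 log units; within the scatter). For compound 4 the estimated value is 55000 nM, with an expected range of 22000 nM to 130000 nM.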

Compound 4, half-maximal cytotoxic concentration: 27400 nM
For compound 4 the middle estimate is 2.0-fold (0.30 log units) above the measured one, and the stated range covers the measured number.
By their numbers in this assay, from the lowest: compounds 3, 2 and 4 (each within the scatter of the next); then compound 1.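

Replacing cyano with hydrogen on the aromatic carbon ortho to a cyano group and para to a large group, which turns 3,4-dicyanophenyl into 3-cyanophenyl, gives a 2.8-fold lower number from compound 1 to compound 4 (0.45 log units; beyond the scatter) in this assay, so the group at this end of the molecule can move the number beyond the scatter, here towards higher toxicity in this test. The only earlier comparison at this group, a 1.2-fold lower number from compound 2 to compound 3 (0.09 log units; within the scatter), had shown no such separation, but it was a different exchange, made on the compound carrying the extra methyl. With a 4.4-fold lower number from compound 1 to compound 3 (0.64 log units; beyond the scatter) alongside it, both single changes shown from compound 1 lower the number, and no information on the origin of the cyano effect is available from any independent measurement.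

The compounds shown leave open whether the same loss of cyano would lower the number on the compound carrying the extra methyl, and whether removing the other cyano would match this step. Also open, as far as these compounds go, is whether the number at this carbon depends on cyano itself, which an amine, a carboxylic acid or a methoxy group there could test.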